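A few compounds are considered here, and "the series" means these few. Any claim that something is new, unique, unknown or untested is made for them only; others in the source may bear on it.

In a functional assay with Mus musculus as the target (on this read-out lower numbers stand for an effect already at smaller amounts and higher numbers for an effect only at larger amounts of compound), compound 1 (`C=CCn1c(=O)n([C@H]2CO[C@@H](CO)C2)c2nc(N)nc(O)c21`) gives 272 uM while compound 2 (`C=CCn1c(=O)n(C2C=CC(CO)O2)c2nc(N)nc(O)c21`) gives 30 uM and compound 3 (`C=CCn1c(=O)n(CCCCO)c2nc(N)nc(O)c21`) gives 52 uM. Compound 2 belongs to the lower pair of these numbers: there is a 1.7-fold higher number from compound 2 to compound 3 (0.24 log units; within the scatter) but a 9.1-fold lower number from compound 1 to compound 2 (0.96 log units; beyond the scatter). Compound 4 (`CCCn1c(=O)n(C2C=CC(CO)O2)c2nc(N)nc(O)c21`) differs from compound 2 by ethyl in place of vinyl on a saturated chain carbon bound to an aromatic nitrogen, allyl to propyl (ethyl in place of vinyl on a saturated chain carbon bound to an aromatic nitrogen). For the measured compounds named here, no measured step touches this group. Even a 5.2-fold lower number from compound 1 to compound 3 (0.72 log units; beyond the scatter) exchanges a different group, so the data give no direct measure, and no step beyond the scatter is expected in this assay. The estimated step is a 1.2-fold higher number from compound 2 to compound 4 (0.07 log units; within the scatter). Compound 4 is expected at 35 uM, within 12 uM to 100 uM.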

Compound 4, concentration for half-maximal effect: 52 uM
Estimate against measurement, compound 4: 1.5-fold (0.17 log units) below; low and high end bracket the measured number.
By their numbers in this assay, from the lowest: compounds 2, 3 and 4 (each within the scatter of the next); then compound 1.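

In this assay, for the compounds shown here, the exchange of allyl for propyl shows a 1.7-fold higher number from compound 2 to compound 4 (0.24 log units; within the scatter) and gives the first measured change on this saturated chain carbon bound to an aromatic nitrogen. With the rest of compound 2 unchanged, this pair shows that the double bond of the allyl group can be lost without a step beyond the scatter. Nothing measured gives a reason for this result.

As far as these compounds go, whether this also holds with the other groups of compound 1 or compound 3 on the aromatic nitrogen remains open. So does the effect of a longer chain, a benzyl group or an amine at this place.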